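Trifluoromethyl Replaces Acetamido at the Para Position

This account rests on a few compounds, and the source may have more. Where it says the series, first, only, none or still open, it means among the compounds named here.

Compound 1 `CC(=O)Nc1ccc(/C=N/Nc2nc(N)c3ncn([C@@H]4O[C@H](CO)[C@@H](O)[C@H]4O)c3n2)cc1` reaches only a limit in an assay on CHO-K1 cells for displacement of a labelled ligand from adenosine receptor A1 (Homo sapiens), read by scintillation counting, with a stated time of 60 min (on this read-out higher numbers stand for weaker inhibition and lower numbers for stronger inhibition), giving > 10000 nM (the limit of > 10000 nM in this assay, at which 1 of the 2 values shown sits). Going by the values given here, its one measured neighbour, compound 2 `N#Cc1ccccc1/C=N/Nc1nc(N)c2ncn([C@@H]3O[C@H](CO)[C@@H](O)[C@H]3O)c2n1`, gives 2.9 nM in this assay. Among the compounds with values here, the step of an at least 3400-fold lower number from compound 1 to compound 2 (3.53 log units; beyond the scatter) is the sole guide. Compound 3 `Nc1nc(N/N=C/c2ccc(C(F)(F)F)cc2)nc2c1ncn2[C@@H]1O[C@H](CO)[C@@H](O)[C@H]1O` carries the change (trifluoromethyl in place of acetamido on an aromatic carbon). That change shares with the measured step only the loss of acetamido; the entering group and its place on the ring differ, so only part of the large measured gain is expected to carry over. The step of an at least 160-fold lower number from compound 1 to compound 3 (2.22 log units; beyond the scatter) is expected, with compound 3 estimated at 60 nM, between 5 nM and 2000 nM.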

Compound 3, inhibition constant: 37 nM
The estimate for compound 3 lay 1.6-fold (0.21 log units) above the measured number; low and high end bracket the measured number.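

In this assay the swap of acetamido for trifluoromethyl, with the place on the ring unchanged, gives an at least 270-fold lower number from compound 1 to compound 3 (2.43 log units; beyond the scatter) and so shows that most of the earlier gain needs neither a nitrile nor a move on the ring. The value of compound 1 is only a limit: the limit of > 10000 nM in this assay, at which 1 of the 3 values shown sits. Even so, the step of a 13-fold higher number from compound 2 to compound 3 (1.11 log units; beyond the scatter) shows that 4-(trifluoromethyl)phenyl does not match 2-cyanophenyl here. As far as these compounds go, whether the nitrile or its place on the ring sets that gap stays open. So does how an amine, a carboxylic acid or a methoxy group would read at this place.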